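The compounds below may be only part of what the source reports. "The series", "measured", "known", "first", "only" and "open" are said of these compounds alone.

Measured so far:
compound 1 `CCc1ccc2ncn(-c3ccnc(N)n3)c2c1`; in an assay on Sf9 cells for inhibition of mitogen-activated protein kinase kinase kinase 14 variant S549D (Homo sapiens), with a stated time of 30 min, in the presence of a further agent that is not named here (on this read-out higher numbers stand for weaker inhibition and lower numbers for stronger inhibition), compound 1 gives 79400 nM
compound 2 `C=CC(=O)NCC#Cc1ccc2ncn(-c3ccnc(N)n3)c2c1`; in this assay compound 2 gives 6310 nM
compound 3 `C=CC(=O)NCCCc1ccc2ncn(-c3ccnc(N)n3)c2c1`; in this assay compound 3 gives 501000 nM

Compound 3 stands highest of the three numbers, beyond the scatter in both directions: a 6.3-fold higher number from compound 1 to compound 3 (0.80 log units; beyond the scatter), and a 79-fold higher number from compound 2 to compound 3 (1.90 log units; beyond the scatter).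

Compound 4 `C=CC(=O)NCCCCc1ccc2ncn(-c3ccnc(N)n3)c2c1` is the next step from compound 3. The change is ((vinylcarbonyl)amino)methyl in place of (vinylcarbonyl)amino on a saturated chain carbon, three bonds along the chain from an aromatic carbon.

Among the measured compounds shown here, no measured step lengthens a saturated chain by one carbon, so none bears directly on this step. The nearest are a 6.3-fold higher number from compound 1 to compound 3 (0.80 log units; beyond the scatter), which introduces the acrylamide unit onto the saturated chain, and a 79-fold higher number from compound 2 to compound 3 (1.90 log units; beyond the scatter), which saturates the three-carbon linker; both leave compound 3 at the weak end of the series. Neither tells how one further chain carbon moves the number, so no step beyond the scatter is expected in this assay, in either direction.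

For compound 4 the estimate in this assay is 400000 nM, range 100000 nM to 1500000 nM, an expected step of a 1.3-fold lower number from compound 3 to compound 4 (0.10 log units; within the scatter).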

Compound 4, half-maximal inhibitory concentration: 501000 nM
For compound 4 the middle estimate is 1.3-fold (0.10 log units) below the measured one; the measured number falls inside the stated range.
By their numbers in this assay, from the lowest: compound 2; then compound 1; then compounds 3 and 4 (each within the scatter of the next).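

In this assay, ((vinylcarbonyl)amino)methyl in place of (vinylcarbonyl)amino on a saturated chain carbon, three bonds along the chain from an aromatic carbon, gives no change at the digits printed from compound 3 to compound 4 (within the scatter), so this one-carbon extension leaves the number where it was. Compound 4 also keeps the weak position relative to the ethyl-bearing compound 1, with a 6.3-fold higher number from compound 1 to compound 4 (0.80 log units; beyond the scatter), and this gap has the same size as a 6.3-fold higher number from compound 1 to compound 3 (0.80 log units; beyond the scatter). Within these two saturated chains, length therefore does not separate the compounds on this read-out.

As far as these compounds go, whether a longer chain would behave the same way, or whether an amine in place of (vinylcarbonyl)amino at the chain end would move the number, remains open. No supporting evidence bears on this result.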